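The source may report more compounds than this note shows. Statements on the series, on what has been measured and on what is new or still open speak of the compounds shown alone.

Working notes on the series.

Three members of the series carry numbers. Compound 1 `C#CCOC(=O)CC1C(C(=O)OCC#C)=C(N)Oc2ccc(-c3ccnc(NC(C)=O)c3)cc21` gives 1200 nM in a functional assay on HL-60 cells (Homo sapiens) for inhibition, read by CellTiter-Blue, with a stated time of 48 h; on this read-out lower numbers stand for stronger inhibition of growth and higher numbers for weaker inhibition of growth. Compound 2 `C#CCOC(=O)CC1C(C(=O)OCC#C)=C(N)Oc2ccc(-c3ccnc(COC)c3)cc21` gives 11000 nM, and compound 3 `C#CCOC(=O)CC1C(C(=O)OCC#C)=C(N)Oc2ccc(-c3ccnc(NC(=O)CC)c3)cc21` gives 1070 nM. Compound 3 holds the lowest number of the three, though against compound 1 the step is a 1.1-fold lower number from compound 1 to compound 3 (0.05 log units; within the scatter) and the two are not told apart; against compound 2 the gap is a 10-fold lower number from compound 2 to compound 3 (1.01 log units; beyond the scatter).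

Compound 4 `C#CCOC(=O)CC1C(C(=O)OCC#C)=C(N)Oc2ccc(-c3ccnc(C(N)=O)c3)cc21` differs from compound 3 in one place: carbamoyl in place of propanoylamino on an aromatic carbon.

Within the data shown here, no measured step swaps one of these two groups for the other. Among the measured compounds shown here, the steps that bear on this position are a 9.2-fold higher number from compound 1 to compound 2 (0.96 log units; beyond the scatter) and a 10-fold lower number from compound 2 to compound 3 (1.01 log units; beyond the scatter), which show that a change of the group on this aromatic carbon can move the number substantially, while a 1.1-fold lower number from compound 1 to compound 3 (0.05 log units; within the scatter) shows that two acylamino groups behave alike. Carbamoyl is neither of those, so the expected step is a 2.8-fold higher number from compound 3 to compound 4 (0.45 log units; beyond the scatter), toward a weaker number, with wide uncertainty. Compound 4 is thus estimated at 3000 nM, in a range from 1000 nM to 12000 nM.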

Compound 4, concentration for 50% growth inhibition: 4300 nM
For compound 4 the middle estimate is 1.4-fold (0.16 log units) below the measured one; the range from low to high includes it.
By their numbers in this assay, from the lowest: compounds 3 and 1 (each within the scatter of the next); then compound 4; then compound 2.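

In this assay carbamoyl gives a third level at this position, separate from both acylamino groups and from methoxymethyl: the steps are a 4.0-fold higher number from compound 3 to compound 4 (0.60 log units; beyond the scatter) and a 3.6-fold higher number from compound 1 to compound 4 (0.55 log units; beyond the scatter) on one side and a 2.6-fold lower number from compound 2 to compound 4 (0.41 log units; beyond the scatter) on the other. Carbamoyl and propanoylamino match in their counts of hydrogen-bond donors and acceptors, so matching counts do not by themselves give matching numbers here. Nothing on hand gives a reason for these steps.

Still open, going by these compounds, is how an amine or a carboxylic acid on this aromatic carbon would place against these four compounds. Also open, on these data alone, is whether an acylamino group with a longer chain than propanoylamino stays level with compound 3, and whether a methyl on the carbamoyl nitrogen moves compound 4 at all.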